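Methylsulfanyl on the benzyl arm of a selenoquinazoline

This account rests on a few compounds, and the source may have more. Where it says the series, first, only, none or still open, it means among the compounds named here.

Measured so far:
compound 1 `CSc1ccc(CNc2nc([SeH])nc3ccccc23)cc1`, 45500 nM
compound 2 `C[Se]c1nc(NCc2ccccc2)c2ccccc2n1`, 74600 nM

In a functional assay on HTB-54 cells (Homo sapiens) for cytotoxicity, read by MTT assay, with a stated time of 72 h (a higher number here means a weaker inhibitor of growth, a lower number a stronger inhibitor of growth), compound 2 gives 74600 nM, the higher of the two numbers. Its nearest neighbour is compound 1, which gives 45500 nM in this assay, a difference that lies within the scatter, so the two cannot be told apart.

Compound 3 `CSc1ccc(CNc2nc([Se]C)nc3ccccc23)cc1` has not been measured. It differs from compound 2 by methylsulfanyl in place of hydrogen on an aromatic carbon, the group sitting on the six-membered aromatic ring of carbon only, para to a large group. Compound 1 already carries this methylsulfanyl group on the same ring and shows no separation from compound 2, so no step beyond the scatter is expected in this assay.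

The estimate for compound 3 in this assay is 55000 nM, within 20000 nM to 150000 nM, which is expected to correspond to a step of a 1.4-fold lower number from compound 2 to compound 3 (0.13 log units; within the scatter).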

Compound 3, concentration for 50% growth inhibition: 37900 nM
Compound 3: middle estimate off by 1.5-fold (0.16 log units), on the high side; measured number inside the range.
By their numbers in this assay, from the lowest: compounds 3, 1 and 2 (each within the scatter of the next).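

In this assay, the change from hydrogen to methylsulfanyl on an aromatic carbon, para to a large group, can now be read directly as a 2.0-fold lower number from compound 2 to compound 3 (0.29 log units; within the scatter), so this group gives no step beyond the scatter in this pair. The second single change, methyl in place of hydrogen on selenium with the methylsulfanyl group kept in place, gives a 1.2-fold lower number from compound 1 to compound 3 (0.08 log units; within the scatter), which also cannot be told apart from no change. No measurement shown here offers an explanation for either step.

On these data alone, whether an amine, a carboxylic acid or a longer chain in place of the methylsulfanyl group would separate from compound 3 in this assay remains open. As far as these compounds go, it is also open whether an ethyl group in place of the methyl on selenium would give a step beyond the scatter.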